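The source may report more compounds than this note shows. Statements on the series, on what has been measured and on what is new or still open speak of the compounds shown alone.

Two members of the series are known: compound 1 `CCCCSC(=S)C1=C(Nc2ccc(Cl)cc2Cl)CC(C)(C)CC1=O` and compound 2 `CCCCCCCCCCCSC(=S)C1=C(Nc2ccc(Cl)cc2Cl)CC(C)(C)CC1=O`. In a functional assay on cells (blood, Homo sapiens) for inhibition, read by chemiluminescence, with a stated time of 30 min (a higher number here means a weaker inhibitor, a lower number a stronger inhibitor), compound 1 gives only a limit of the assay, > 100 ug/mL. In this assay compound 2 likewise gives only a limit, > 100 ug/mL. The step that the two limits leave unreadable from compound 1 to compound 2 thus cannot be read, since both values sit at the limit of > 100 ug/mL in this assay, at which 2 of the 2 values shown sit. Compound 3 `CC1(C)CC(=O)C(C(=S)SCc2ccccc2)=C(Nc2ccc(Cl)cc2Cl)C1` is the next member and differs from compound 2 by phenyl in place of decyl on a saturated chain carbon bound to a sulfur. Among the compounds with values here, no measured step bears readably on this change. Compound 3 is expected to give 150 ug/mL, within 40 ug/mL to 500 ug/mL, most likely again only a limit, so the expected step is a step that the limit leaves unreadable from compound 2 to compound 3.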

Compound 3, half-maximal inhibitory concentration: > 100 ug/mL
Compound 3 ended at the assay's limit (the forecaster's own chance of this, stated with the estimate: 80%); the middle value does not contradict the limit.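

No step among compound 1, compound 2 and compound 3 can be read in this assay, since all three values are limits: the limit of > 100 ug/mL in this assay, at which 3 of the 3 values shown sit.

The compounds shown leave open how decyl, propyl and phenyl differ in their bearing on inhibition, and whether any member gives a measurable value.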